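The source may hold more compounds than are shown below. What is called first, only, known or untested is meant among the compounds shown, and "the series" means these compounds.

Three compounds have been measured in a functional assay on PC-3 cells (Homo sapiens) for cytotoxicity, read by sulforhodamine B assay; a higher number here means a weaker inhibitor of growth, a lower number a stronger inhibitor of growth:

Compound 1, `COc1cccc(OC)c1OCCNCCOc1ccccc1OCc1cccc(C)c1`: 12000 nM
Compound 2, `COc1cccc(OC)c1OCCNCCOc1ccccc1OCc1cccc([N+](=O)[O-])c1`: 13200 nM
Compound 3, `COc1cccc(OC)c1OCCNCCOc1ccccc1OCc1ccc([N+](=O)[O-])cc1`: 12000 nM

All three share the same core and differ only in the group carried on the benzyl part. Compound 3 sits level with compound 1, the two values being identical at the digits shown. The step involving the remaining pair is a 1.1-fold lower number from compound 2 to compound 3 (0.04 log units; within the scatter), which is within the scatter. Every step among the three is small: a 1.1-fold higher number from compound 1 to compound 2 (0.04 log units; within the scatter) and no change at the digits printed from compound 1 to compound 3 (within the scatter), both within the scatter.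

Compound 4, `CCOc1ccc(COc2ccccc2OCCNCCOc2c(OC)cccc2OC)cc1`, is the next compound to be measured. It differs from compound 3 by ethoxy in place of nitro on an aromatic carbon. The measured steps that bear on this are those that alter the same part of the molecule: swapping methyl for nitro, and moving the nitro to another position, neither of which shifted the number beyond the scatter. No step beyond the scatter is therefore expected in this assay. Compound 4 is estimated to give about 12000 nM, with a range from 6000 nM to 24000 nM. The expected change in this assay is no change at the digits printed from compound 3 to compound 4 (within the scatter).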

Compound 4, concentration for 50% growth inhibition: 5200 nM
Compound 4: middle estimate off by 2.3-fold (0.36 log units), on the high side; measured number below the stated range.
By their numbers in this assay, from the lowest: compound 4; then compounds 1, 3 and 2 (each within the scatter of the next).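

In this assay, going by these compounds alone, this position proves able to move the number: ethoxy in place of nitro on the aromatic carbon para to a large group gives a 2.3-fold lower number from compound 3 to compound 4 (0.36 log units; beyond the scatter) while the methyl and nitro changes among the earlier compounds all stayed within the scatter. The comparisons with the other two compounds agree, with a 2.5-fold lower number from compound 2 to compound 4 (0.40 log units; beyond the scatter) and a 2.3-fold lower number from compound 1 to compound 4 (0.36 log units; beyond the scatter) showing that compound 4 stands apart from all three earlier compounds, although each step is modest. No measurement shown gives a reason for this shift.

From the compounds shown here alone, it remains open whether a shorter methoxy, a longer butoxy or an amine at this same position would give a similar number. Also open, going by these compounds, is whether ethoxy would have the same effect at the ring position that carries the nitro in compound 2.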